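Hydroxyl Position on Two Related Cores

A few compounds are considered here, and "the series" means these few. Any claim that something is new, unique, unknown or untested is made for them only; others in the source may bear on it.

Compound 1, `Oc1cccc(-c2cc(-c3ccccc3)cc(-c3cccs3)n2)c1`, gives 51.2%.
Compound 2, `Oc1ccc(-c2cc(-c3ccccc3)cc(-c3cccs3)n2)cc1`, gives 4.9%.
Compound 3, `Oc1cccc(-c2cc(-c3ccccc3)nc(-c3ccco3)c2)c1`, gives 48.8%.

These values come from an assay on isolated protein for inhibition of DNA topoisomerase 1 (Homo sapiens), with a stated time of 30 min, tested at 100 uM; on this read-out lower numbers stand for a weaker effect and higher numbers for a stronger effect at the one concentration tested. The change 4-hydroxyphenyl in place of 3-hydroxyphenyl on an aromatic carbon produces a number 46.3 percentage points lower from compound 1 to compound 2 (beyond the scatter). Compound 3 sits near compound 1; the difference between the two cores is not broken down here. Compound 4, `Oc1ccc(-c2cc(-c3ccccc3)nc(-c3ccco3)c2)cc1`, differs from compound 3 by 4-hydroxyphenyl in place of 3-hydroxyphenyl on an aromatic carbon. This is the same kind of change as that from compound 1 to compound 2, though the place differs: in compound 3 the group is meta to a furan-2-yl group and opposite the ring nitrogen, whereas in compound 1 it is next to the ring nitrogen and meta to a thiophen-2-yl group. Because a number 46.3 percentage points lower from compound 1 to compound 2 (beyond the scatter) was large, a step of comparable size is expected, a number 40.8 percentage points lower from compound 3 to compound 4 (beyond the scatter), with less certainty given the different core. Compound 4 is therefore estimated at 8%, between 0% and 30% in this assay.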

Compound 4, a percentage reported as inhibition, at one concentration (the size of the read-out at that concentration, not a potency): 5%
The estimate for compound 4 lay 3 percentage points above the measured number; the range from low to high includes it.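

In this assay, 4-hydroxyphenyl in place of 3-hydroxyphenyl gives a number 43.8 percentage points lower from compound 3 to compound 4 (beyond the scatter). The change therefore carries over between the core of compound 1 and the core of compound 3, with steps that cannot be told apart: the same change on two cores in this assay, a number 46.3 percentage points lower (beyond the scatter) from compound 1 to compound 2 and a number 43.8 percentage points lower (beyond the scatter) from compound 3 to compound 4, 2.5 percentage points apart, within the scatter of two such steps. Among the compounds shown here, this rests on only two pairs tested at a single concentration, so it shows neither how potency changes nor whether the step would hold on any other core.

The compounds shown leave open whether a methoxy group or an amine would behave like the hydroxyl group on either phenyl ring. They also leave open what the thiophen-2-yl and furan-2-yl groups each contribute, as no pair shown differs in that group alone.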